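The source may report more compounds than this note shows. Statements on the series, on what has been measured and on what is new or still open speak of the compounds shown alone.

Measured compounds:
- compound 1 `N/C(=N\NC(=S)N1CCCC1)c1ccc(F)cn1`: 72.2%
- compound 2 `Cc1cccc(/C(N)=N/NC(=S)N2CCSCC2)n1`: 51.7%
- compound 3 `N/C(=N\NC(=S)N1CCCCC1)c1ccccn1`: 27%

In a functional assay on A-431 cells (Homo sapiens) for cytotoxicity, read by MTT assay, with a stated time of 72 h, tested at 3 uM (on this read-out lower numbers stand for less inhibition of growth and higher numbers for more inhibition of growth at the one concentration tested), compound 1 gives the highest of the three numbers. Compound 2 is the nearest to it, and its value lies beyond the scatter below that of compound 1; compound 3 is the furthest away, also beyond the scatter. No two of the measured compounds differ in only one place, so no single change can be read off directly from these values.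

Compound 4 `N/C(=N\NC(=S)N1CCSCC1)c1ccc(F)cn1` has not yet been measured in this assay. It differs from compound 1 by thiomorpholin-4-yl in place of pyrrolidin-1-yl on a thiocarbonyl carbon. The same thiomorpholin-4-yl group is present in compound 2, which gives 51.7%, but compound 2 also carries a different pyridine substituent, so its value cannot be taken as a clean measure of this change.

Compound 4 is expected to sit below compound 1, with the step of a number 20.2 percentage points lower from compound 1 to compound 4 (beyond the scatter) estimated to lie beyond the scatter. Compound 4 is therefore estimated at 52%, with a range from 30% to 75%.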

Compound 4, percent growth inhibition at one concentration: 61.2%
Compound 4: the middle estimate sits 9.2 percentage points below what was measured; the range from low to high includes it.
By their numbers in this assay, from the lowest: compound 3; then compounds 2 and 4 (each within the scatter of the next); then compound 1.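

In this assay, within the data shown here, compound 1 and compound 4 give the first clean reading of the group on the thiocarbonyl carbon: placing thiomorpholin-4-yl where pyrrolidin-1-yl stood gives a modest step (a number 11 percentage points lower from compound 1 to compound 4 (beyond the scatter)). The step lies beyond the scatter, so this place does respond to the choice of ring, yet compound 4 still reaches 61.2% at the one concentration tested, and the six-membered ring with its sulfur keeps much of the growth inhibition. Nothing measured here explains the step.

Whether the same exchange gives a step of this size on the other cores shown cannot be read from these compounds. They also leave open how a morpholin-4-yl, a piperazin-1-yl or an open-chain dimethylamino group would compare at this place.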